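The source may hold more compounds than are shown below. What is called first, only, known or untested is meant among the compounds shown, and "the series" means these compounds.

Measured compounds:

Compound 1 `CC(C)N(Cc1cccc(OCCCCCC(=O)O)c1)C(=O)c1ccc(-c2cccc(Cl)c2)cc1`; in an ADME assay on BJ cells (Homo sapiens) for cytotoxicity, read by CellTiter-Glo and resazurin assay, with a stated time of 72 h (a lower number here means that less compound is needed, a higher number that more compound is needed for the effect), compound 1 gives only a limit, > 21900 nM.
Compound 2 `CC(C)N(Cc1cccc(OCCCCCC(=O)O)c1)C(=O)c1ccc(-c2cccc(S(C)(=O)=O)c2)cc1`; in this assay compound 2 gives only a limit, > 26000 nM.
Compound 3 `CCOC(=O)CCCCCOc1cccc(CN(C(=O)c2ccc(-c3cccc(Cl)c3)cc2)C(C)C)c1`; in this assay compound 3 gives only a limit, > 18400 nM.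

All three values in this assay are limits, so none of the compounds shows a readable number. The change from compound 1 to compound 2 is methylsulfonyl in place of chloro on an aromatic carbon, and its step, a step that the two limits leave unreadable from compound 1 to compound 2, cannot be sized since both ends sit at limits, the limit of > 21900 nM in this assay, at which 1 of the 3 values shown sits, and (the limit of > 26000 nM in this assay, at which 1 of the 3 values shown sits). The cores of compound 1 and compound 3 differ by ethyl in place of hydrogen on an oxygen next to a carbonyl group, and the step that the two limits leave unreadable from compound 1 to compound 3 is likewise unreadable, with the limit of > 18400 nM in this assay, at which 1 of the 3 values shown sits, at one end.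

Compound 4 `CCOC(=O)CCCCCOc1cccc(CN(C(=O)c2ccc(-c3cccc(S(C)(=O)=O)c3)cc2)C(C)C)c1` is not yet measured. It differs from compound 3 by methylsulfonyl in place of chloro on an aromatic carbon, the same change as that from compound 1 to compound 2, made at a place described in the same words. The expectation for compound 4 rests on the fact that every measured value is a limit: because the limit of > 18400 nM in this assay, at which 1 of the 3 values shown sits, marks compound 3 as showing no effect up to that limit, and because the limit of > 21900 nM in this assay, at which 1 of the 3 values shown sits, and the limit of > 26000 nM in this assay, at which 1 of the 3 values shown sits, show the same change giving no readable effect between compound 1 and compound 2, the step that the limit leaves unreadable from compound 3 to compound 4 is expected to stay unreadable in the same way. For compound 4 the estimate is 30000 nM, with a range from 15000 nM to 80000 nM, most likely reported again as a limit only.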

Compound 4, half-maximal effective concentration: > 26000 nM
Compound 4 gave a limit, no number; the forecaster's own chance of this, stated with the estimate: 85%; the middle value is on the limit's open side.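

In this assay neither the step between compound 3 and compound 4 nor the step between compound 2 and compound 4 can be read: each has a limit at both ends, and no size follows from limits. The compounds shown leave open at what concentration, if any, compound 1, compound 2, compound 3 or compound 4 reaches the half-maximal effect, and whether either change shifts that concentration.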